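Replacing a Silyl Ether with an Acetyl Ester

The source may report more compounds than this note shows. Statements on the series, on what has been measured and on what is new or still open speak of the compounds shown alone.

Compound 3 `C=CCCC1=NCC(O[Si](C)(C)C(C)(C)C)c2cc(OC)c(OC)cc21` was tested in an ADME assay on HEK293 cells (Homo sapiens) for cytotoxicity, read by CellTiter-Glo and resazurin assay, with a stated time of 72 h; on this read-out lower numbers stand for an effect already at smaller amounts and higher numbers for an effect only at larger amounts of compound. In this assay compound 3 gives > 13000 nM, which is a limit of the assay and not a number. Two further compounds from the same series, compound 1 `CC(C)N(Cc1cccc(OCCCCCC(=O)O)c1)C(=O)c1ccc(-c2cccc(OC(F)(F)F)c2)cc1` and compound 2 `CCOC(=O)CCCCCOc1cccc(CN(C(=O)c2ccc(-c3ccc4cc[nH]c4c3)cc2)C(C)C)c1`, were tested alongside it. In this assay compound 1 gives > 26000 nM, again only a limit. In this assay compound 2 gives > 26000 nM, likewise a limit. All three values therefore sit at limits: the limit of > 13000 nM in this assay, at which 1 of the 3 values shown sits, and (the limit of > 26000 nM in this assay, at which 2 of the 3 values shown sit). Compound 3 thus stands at a limit, and no order among the three compounds can be read from these numbers.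

Compound 4 `C=CCCC1=NCC(OC(C)=O)c2cc(OC)c(OC)cc21` differs from compound 3 in one place: a group of 3 heavy atoms (2 carbon, 1 oxygen; no ring) in place of a group of 7 heavy atoms (6 carbon, 1 silicon; no ring), on an oxygen on a saturated carbon. For the measured compounds named here, no step between two measured compounds is available here, since every measured value is a limit. The step from compound 3 to compound 4 is expected to be a step that the limit leaves unreadable from compound 3 to compound 4, that is, nothing beyond the usual scatter. Compound 4 is therefore expected to give 20000 nM in this assay, within a range from 7000 nM to 60000 nM.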

Compound 4, half-maximal effective concentration: > 13000 nM
Compound 4: only a limit was reported; the forecaster's own chance of this, stated with the estimate: 75%; the middle value lies beyond the limit too.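

In this assay, for the compounds shown here, compound 3 and compound 4 both stand only at limits of the assay, so no step between them can be read. The compounds shown leave open whether acetyl in place of the group of 7 heavy atoms alters cytotoxicity at all, and at what concentration any of these compounds would reach a half-maximal effect.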